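Swapping a Chlorophenyl for a Bromophenyl on a Weak Core

The compounds below may be only part of what the source reports. "The series", "measured", "known", "first", "only" and "open" are said of these compounds alone.

Compound 1 `COc1ccc(Nc2nc(-c3cccc(F)c3)nc3ccc(F)cc23)cc1` gives 48400 nM in a functional assay on MCF7 cells (Homo sapiens) for cytotoxicity, read by MTT assay, with a stated time of 48 h; a higher number here means a weaker inhibitor, a lower number a stronger inhibitor.
Compound 2 `Fc1cccc(-c2nc(Nc3ccccc3Cl)c3cc(F)ccc3n2)c1` gives > 50000 nM in this assay, which is a limit of the assay and not a number.

Compound 2 therefore stands at the edge of what this assay can report; one of the two values sits at the limit of > 50000 nM in this assay, at which 1 of the 2 values shown sits. Going by the values given here, the only measured step, an at least 1.0-fold higher number from compound 1 to compound 2 (0.01 log units; that floor lies within the scatter), stayed within the scatter. Compound 3 `Fc1cccc(-c2nc(Nc3ccc(Br)cc3)c3cc(F)ccc3n2)c1` carries 4-bromophenyl in place of 2-chlorophenyl on a nitrogen on an aromatic ring. Going from compound 2, no step beyond the scatter is expected, so a step that the limit leaves unreadable from compound 2 to compound 3 is the estimate. Compound 3 is expected to give 60000 nM, within 25000 nM to 150000 nM.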

Compound 3, half-maximal inhibitory concentration: > 50000 nM
Compound 3 ended at the assay's limit; the forecaster's own chance of this, stated with the estimate: 65%; the middle value lies beyond the limit too.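

For compound 3, the reading in this assay is a limit of the assay and not a number. The swap of 2-chlorophenyl for 4-bromophenyl on this nitrogen therefore cannot be read as a step, while bromo in place of methoxy gives an at least 1.0-fold higher number from compound 1 to compound 3 (0.01 log units; that floor lies within the scatter). Moving the halogen and changing it both leave the compound at the same ceiling: the limit of > 50000 nM in this assay, at which 2 of the 3 values shown sit.

As far as these compounds go, what a phenyl ring carrying an amine or a carboxylic acid would give on this nitrogen stays open. So does whether any group here can bring the number well under the limit.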